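This account rests on a few compounds, and the source may have more. Where it says the series, first, only, none or still open, it means among the compounds named here.

Measured compounds:
compound 1 `CC(C)=CCC[C@]1(C)/C=C/[C@@H](OC(=O)C=C(C)C)[C@](C)(O)/C=C/C(=O)/C(CF)=C\C1` — 240 nM
compound 2 `CC(=O)OC/C1=C/C[C@](C)(CCC=C(C)C)/C=C/[C@@H](OC(=O)C=C(C)C)[C@](C)(O)/C=C/C1=O` — 4510 nM
compound 3 `CC(C)=CCC[C@]1(C)/C=C/[C@@H](OC(=O)C=C(C)C)[C@](C)(O)/C=C/C(=O)/C(CN(C(C)C)C(C)C)=C\C1` — 780 nM

In a functional assay on MCF7 cells (Homo sapiens) for antiproliferative activity, read by MTT assay, with a stated time of 48 h (on this read-out lower numbers stand for stronger inhibition and higher numbers for weaker inhibition), compound 1 gives the lowest of the three numbers; compound 3 comes nearest with a 3.3-fold higher number from compound 1 to compound 3 (0.51 log units; beyond the scatter), and compound 2 lies furthest with a 19-fold higher number from compound 1 to compound 2 (1.27 log units; beyond the scatter). Between the other two, a 5.8-fold lower number from compound 2 to compound 3 (0.76 log units; beyond the scatter).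

Compound 4 `CC(C)=CCC[C@]1(C)/C=C/[C@@H](OC(=O)C=C(C)C)[C@](C)(O)/C=C/C(=O)/C(C(=O)N(C)C)=C\C1` has not yet been measured in this assay. It differs from compound 1 in one place: dimethylcarbamoyl in place of fluoromethyl on a double-bonded ring carbon. The group that leaves is the fluoromethyl; the group that enters, dimethylcarbamoyl, is larger and carries one hydrogen-bond acceptor, and it sits directly on the double-bonded ring carbon of the non-aromatic ring of carbon only.

The two measured steps from compound 1 both replace the fluoro on the saturated chain carbon with another group, and both raise the number: modestly in the step to compound 3, and strongly in the step to compound 2. Neither step removes the chain carbon itself, so they bear on the change to compound 4 only loosely, yet both point the same way, toward a weaker compound. Compound 4 is therefore expected to give a higher number than compound 1, by a modest step of about a 6.3-fold higher number from compound 1 to compound 4 (0.80 log units; beyond the scatter). The estimate for compound 4 is 1500 nM, with a range from 400 nM to 6000 nM.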

Compound 4, half-maximal inhibitory concentration: 3670 nM
Beside the measured number, compound 4's estimate is 2.4-fold (0.39 log units) below it; the range from low to high includes it.
By their numbers in this assay, from the lowest: compound 1; then compound 3; then compounds 4 and 2 (each within the scatter of the next).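

In this assay, placing dimethylcarbamoyl directly on the double-bonded ring carbon, with no saturated chain carbon left in between, gives a large step (a 15-fold higher number from compound 1 to compound 4 (1.18 log units; beyond the scatter)), so this position has now been probed by a change to the attached carbon itself, not only by a change of the group on the chain carbon. The same group also falls short of the amine-bearing compound (a 4.7-fold higher number from compound 3 to compound 4 (0.67 log units; beyond the scatter)), yet it cannot be told apart from the acetoxymethyl compound (a 1.2-fold lower number from compound 2 to compound 4 (0.09 log units; within the scatter)), and so among these four compounds, fluoromethyl remains the group with the lowest number, while two differently attached carbonyl-bearing groups read alike. Nothing measured here accounts for these differences.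

The compounds shown leave open whether the low number of compound 1 follows from the fluorine or simply from a small group at this carbon, which a plain methyl, a hydroxymethyl or a difluoromethyl group could separate. They also leave open how a carboxylic acid, a primary amide or a smaller aminomethyl group such as dimethylaminomethyl would read at this same ring carbon.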